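Fluoro on the Benzyl Group: An Expected Small Change

The compounds below may be only part of what the source reports. "The series", "measured", "known", "first", "only" and "open" are said of these compounds alone.

Three compounds have been measured in an assay on isolated protein for inhibition of DNA nucleotidylexotransferase (Homo sapiens), read by scintillation counting, with a stated time of 10 min; a higher number here means a weaker inhibitor, a lower number a stronger inhibitor:
compound 1 `CCOC(=O)C(=O)CC(=O)/C=C/c1cc(C(=O)c2ccccc2)cn1Cc1ccccc1` gives > 40 uM, which is a limit of the assay and not a number.
compound 2 `CCOC(=O)C(=O)CC(=O)/C=C/c1cc(C(=O)c2ccccc2)cn1Cc1ccc(F)cc1` gives > 40 uM, also a limit of the assay.
compound 3 `O=C(/C=C/c1cc(C(=O)c2ccccc2)cn1Cc1ccccc1)CC(=O)C(=O)O` gives 16 uM.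

Within the data shown here, compound 3 therefore stands as the only compound of the three with a measured number; the other two results sit at the limit of > 40 uM in this assay, at which 2 of the 3 values shown sit. Among the measured compounds shown here, the one readable step is an at least 2.5-fold lower number from compound 1 to compound 3 (0.39 log units; beyond the scatter), brought about by hydrogen in place of ethyl on an oxygen next to a carbonyl group. The step that the two limits leave unreadable from compound 1 to compound 2 cannot be sized: both of its ends are limits.

Compound 4 `O=C(/C=C/c1cc(C(=O)c2ccccc2)cn1Cc1ccc(F)cc1)CC(=O)C(=O)O` differs from compound 3 by fluoro in place of hydrogen on an aromatic carbon. The same change, from compound 1 to compound 2, left no readable step, so nothing measured shows how fluoro in place of hydrogen on an aromatic carbon shifts the result in this assay. For the measured compounds named here, with no measured step to build on, the step of no change at the digits printed from compound 3 to compound 4 (within the scatter) is expected to stay within the usual scatter. Compound 4 is accordingly estimated to give about 16 uM in this assay, most likely between 5 uM and 50 uM.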

Compound 4, concentration for 50% inhibition: 9.5 uM
Compound 4: the middle estimate sits 1.7-fold (0.23 log units) above what was measured; the measured number falls inside the stated range.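

The change from benzyl to 4-fluorobenzyl can now be sized in this assay, which the earlier pair of limits did not allow: a 1.7-fold lower number from compound 3 to compound 4 (0.23 log units; within the scatter). Fluoro in this place therefore leaves the result where it was, at least on this core, and the two compounds cannot be told apart in this assay. Hydrogen in place of ethyl also now proves readable a second time, on the core that carries the 4-fluorobenzyl group, with an at least 4.2-fold lower number from compound 2 to compound 4 (0.62 log units; beyond the scatter), so the earlier step was not confined to the plain benzyl core, although its size on the two cores cannot be compared: the same change on two cores in this assay, an at least 2.5-fold lower number (0.39 log units; beyond the scatter) from compound 1 to compound 3 and an at least 4.2-fold lower number (0.62 log units; beyond the scatter) from compound 2 to compound 4; the limit leaves it open whether they differ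

Going by these compounds, the ethyl compounds still give no true number on either core, so the effect of fluoro with ethyl in place cannot be read: the limit of > 40 uM in this assay, at which 2 of the 4 values shown sit. Whether chloro, methoxy or trifluoromethyl in this same place would shift the result beyond the scatter remains open, as does whether an amide or a methyl ester would stand closer to the hydrogen compounds or to the ethyl ones.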